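The compounds below may be only part of what the source reports. "The series", "measured", "known", "first", "only" and "open" are said of these compounds alone.

Measured so far in a physicochemical assay for solubility, in phosphate buffer, at pH 7.4; a higher number here means a more soluble compound, a lower number a less soluble compound:
- Compound 1 `CCOC(=O)c1c(-c2cccc(C)c2)[nH]c2cc(OC)ccc2c1=O`: 48000 nM
- Compound 2 `CCOC(=O)c1c(-c2cccc(F)c2)[nH]c2cccc(OC)c2c1=O`: > 100000 nM, a limit of the assay
- Compound 3 `CCOC(=O)c1c(-c2cccc(OC)c2)[nH]c2cc(OC)ccc2c1=O`: > 100000 nM, a limit of the assay

Compound 2 has no exact number, only (the limit of > 100000 nM in this assay, at which 2 of the 3 values shown sit). Unmeasured compound 4 `CCOC(=O)c1c(-c2ccccc2C)[nH]c2cccc(OC)c2c1=O` carries 2-methylphenyl in place of 3-fluorophenyl on an aromatic carbon.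

Going by the values given here, only one measured step changes a group on this same aromatic ring: an at least 2.0-fold higher number from compound 1 to compound 3 (0.31 log units; beyond the scatter), with methoxy in place of methyl. That step involves neither compound 2 nor compound 4, so it is only a loose guide. It does show that a methyl-bearing compound can give a real number, since compound 1 gives 48000 nM. Given that value for compound 1, a modest fall in this assay is expected, though a result at the limit remains possible. The expected change is an at least 1.6-fold lower number from compound 2 to compound 4 (0.22 log units; that floor lies within the scatter). Compound 4 is estimated at 60000 nM, with an expected range of 25000 nM to 100000 nM.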

Compound 4, solubility: > 100000 nM
Compound 4 was reported as a limit (the forecaster's own chance of this, stated with the estimate: 35%); middle value at least 1.6-fold (0.22 log units) away from the limit.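

Compound 2 and compound 4 both give only a limit in this assay, not an exact number, so no step can be read between them: the limit of > 100000 nM in this assay, at which 3 of the 4 values shown sit.

Going by these compounds, whether 2-methylphenyl in place of 3-fluorophenyl changes the number at all, and in which direction, stays open.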